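The compounds below may be only part of what the source reports. "The series", "measured", "known", "first", "only" and "open" are said of these compounds alone.

Compound 1, `Cc1nc(N)sc1CCCN/C(N)=N/C(=O)NC(C)c1ccc(Br)cc1`, gives 55 nM.
Compound 2, `Cc1nc(N)sc1CCCN/C(N)=N/C(=O)N[C@@H](C)c1ccccc1`, gives 23.4 nM.
Compound 3, `Cc1nc(N)sc1CCCN/C(N)=N/C(=O)NC(c1ccccc1)C(C)C`, gives 34.7 nM.

These three compounds were tested in a functional assay on Right cardiac atrium for agonist activity at histamine H2 receptor (Cavia porcellus), with a stated time of 30 min, in the presence of a further agent that is not named here; a lower number here means that less compound is needed, a higher number that more compound is needed for the effect. Compound 1 stands at the highest number of the three: compound 3 sits within the scatter of it, while compound 2 lies a little beyond the scatter, at a lower number. The new compound 4, `Cc1nc(N)sc1CCCN/C(N)=N/C(=O)NC(C)c1ccc(F)cc1`, differs from compound 1 in one place: fluoro in place of bromo on an aromatic carbon, so that a 4-bromophenyl becomes a 4-fluorophenyl. Going by the values given here, no measured pair shows this exchange, and compound 2, which carries no such group at all, stands only modestly lower than compound 1. The step of a 1.4-fold lower number from compound 1 to compound 4 (0.16 log units; within the scatter) is therefore expected to be small, likely within the scatter. Compound 4 is estimated at 38 nM, with a range from 15 nM to 95 nM.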

Compound 4, half-maximal effective concentration: 23.4 nM
Compound 4: middle estimate off by 1.6-fold (0.21 log units), on the high side; the measured number falls inside the stated range.
By their numbers in this assay, from the lowest: compounds 2, 4, 3 and 1 (each within the scatter of the next, the first and the last beyond it).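

Going by these compounds alone, exchanging bromo for fluoro on the phenyl ring gives the first single-place comparison at this position, and the step is modest but beyond the usual scatter (a 2.4-fold lower number from compound 1 to compound 4 (0.37 log units; beyond the scatter)). The group at this place on the ring therefore affects how much compound is needed, and fluoro needs less than bromo here. Nothing measured here accounts for this step. On these data alone, how chloro, methoxy or a nitrile at the same place would compare remains open. So does whether the same exchange would give a similar step on the core of compound 3.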